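Adding a methyl to the chain of compound 2

The source may report more compounds than this note shows. Statements on the series, on what has been measured and on what is new or still open speak of the compounds shown alone.

- compound 1 `CCCCCCCCC(CCO)n1cnc2c(OC)ncnc21`: 12800 nM
- compound 2 `CCCCCCCCC(CCO)n1cnc2c(NC)ncnc21`: 3730 nM
- compound 3 `CCCCCCCCC(CCO)n1cnc2c(N)ncnc21`: 11600 nM

In a functional assay on HCT-116 cells (Homo sapiens) for antiproliferative activity, read by MTT assay, with a stated time of 48 h (a lower number here means a stronger inhibitor, a higher number a weaker inhibitor), compound 2 holds the lowest of the three numbers, with modest steps on either side: a 3.4-fold lower number from compound 1 to compound 2 (0.54 log units; beyond the scatter) and a 3.1-fold higher number from compound 2 to compound 3 (0.49 log units; beyond the scatter). Compound 4 `CCCCCCCCCC(CCO)n1cnc2c(NC)ncnc21` differs from compound 2 by methyl in place of hydrogen on a saturated chain carbon, nine bonds along the chain from an aromatic nitrogen. The measured steps all change the group on the aromatic carbon or its nitrogen, and none changes the chain, so they give no direct guide and no direction. No step beyond the scatter is expected in this assay. The estimated step is a 1.2-fold lower number from compound 2 to compound 4 (0.07 log units; within the scatter). Compound 4 is estimated at 3200 nM, with an expected range of 1500 nM to 7000 nM.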

Compound 4, half-maximal inhibitory concentration: 5410 nM
Compound 4: middle estimate off by 1.7-fold (0.23 log units), on the low side, within the range that was stated.
By their numbers in this assay, from the lowest: compounds 2 and 4 (each within the scatter of the next); then compounds 3 and 1 (each within the scatter of the next).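

In this assay, among these compounds, the first change to the chain gives a 1.5-fold higher number from compound 2 to compound 4 (0.16 log units; within the scatter) and, unlike the modest steps at the group on the aromatic carbon, leaves compound 2 and compound 4 indistinguishable. Methyl in place of hydrogen, nine bonds along the chain from an aromatic nitrogen, is therefore accommodated in this assay without a step beyond the scatter. No measured evidence bears on this result. Going by these compounds, whether a much longer chain, or an amine or carboxylic acid in place of that methyl, would shift the number remains open.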